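Swapping the ethylpiperazine of compound 3 for a hydroxypiperidine

The compounds below may be only part of what the source reports. "The series", "measured", "known", "first", "only" and "open" are said of these compounds alone.

Among the three compounds measured in an ADME assay on HEK293-A cells (Homo sapiens) for cytotoxicity, read by MTT assay, with a stated time of 48 h (a higher number here means a weaker inhibitor, a lower number a stronger inhibitor), compound 3 `CCN1CCN(C[C@H]2CN(c3ccc(-n4cc(-c5ccccn5)cn4)c(F)c3)C(=O)O2)CC1` is the only one with a number: compound 3 gives 99 ug/mL. Compound 1 `O=C1O[C@@H](CO)CN1c1ccc(-n2cc(-c3ccccn3)cn2)c(F)c1` returns a limit of the assay, > 400 ug/mL. Compound 2 `CN(CCC#N)C[C@H]1CN(c2ccc(-n3cc(-c4ccccn4)cn3)c(F)c2)C(=O)O1` also returns a limit, > 400 ug/mL. Both of these sit at the limit of > 400 ug/mL in this assay, at which 2 of the 3 values shown sit. Among the compounds with values here, the steps that bear on the new compound are an at least 4.0-fold lower number from compound 1 to compound 3 (0.60 log units; beyond the scatter) and an at least 4.0-fold lower number from compound 2 to compound 3 (0.60 log units; beyond the scatter). Compound 4 `O=C1O[C@@H](CN2CCC(O)CC2)CN1c1ccc(-n2cc(-c3ccccn3)cn2)c(F)c1` differs from compound 3 by 4-hydroxypiperidin-1-yl in place of 4-ethylpiperazin-1-yl on a saturated chain carbon bound to a saturated ring carbon, bringing back a hydroxy-bearing group. Because an at least 4.0-fold lower number from compound 1 to compound 3 (0.60 log units; beyond the scatter) ran toward a stronger inhibitor, compound 4 is expected to move part of the way back, a step of a 3.0-fold higher number from compound 3 to compound 4 (0.48 log units; beyond the scatter). Compound 4 is thus estimated at 300 ug/mL, between 120 ug/mL and 600 ug/mL.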

Compound 4, half-maximal inhibitory concentration: > 400 ug/mL
Compound 4 gave a limit, no number; the forecaster's own chance of this, stated with the estimate: 55%; at least 1.3-fold (0.12 log units) between middle value and limit.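

In this assay, placing 4-hydroxypiperidin-1-yl in place of 4-ethylpiperazin-1-yl gives an at least 4.0-fold higher number from compound 3 to compound 4 (0.60 log units; beyond the scatter), so a six-membered ring on this saturated chain carbon does not by itself bring the lower number. The steps from compound 1 and compound 2 to compound 4 cannot be read, since both ends of each are limits. Compound 3 remains the only compound with a number, and the others share one limit: the limit of > 400 ug/mL in this assay, at which 3 of the 4 values shown sit.

The compounds shown leave open whether the ethyl group or the second ring nitrogen of compound 3 matters more. An unsubstituted piperazine or a morpholine at this position could separate the two.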